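A few compounds are considered here, and "the series" means these few. Any claim that something is new, unique, unknown or untested is made for them only; others in the source may bear on it.

Measured compounds:
compound 1 `C=CCc1ccc(OCc2cn(-c3ccc(C#N)cc3)nn2)c(O)c1`: 35.6%
compound 2 `C=CCc1ccc(OCc2cn(-c3cc(OC)c(OC)c(OC)c3)nn2)c(O)c1`: 38.1%

Both values come from a functional assay on MCF7 cells (Homo sapiens) for inhibition, read by MTT assay, with a stated time of 72 h, tested at 50 uM (on this read-out higher numbers stand for more inhibition of growth at the one concentration tested and lower numbers for less inhibition of growth), and lie within the scatter of each other, so the two compounds cannot be ranked. Among the measured compounds shown here, compound 1 therefore stands level with the only other measured compound, and its value (35.6%) serves as the starting point here.

The next compound to be measured is compound 3 `C=CCc1ccc(OCc2cn(-c3cccc(C#N)c3)nn2)c(O)c1`, which has the same atoms as compound 1, joined differently. It carries 3-cyanophenyl in place of 4-cyanophenyl on an aromatic nitrogen.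

For the measured compounds named here, no pair of measured compounds differs in one place, so the data hold no direct guide to this change. Going by the values given here, the only anchor is the value of compound 1 (35.6%), and no direction can be argued from it. The expected outcome is a step no larger than the scatter, in either direction (a number 0.4 percentage points higher from compound 1 to compound 3 (within the scatter)).

In this assay compound 3 is estimated at 36% with an expected range from 24% to 49% for a single measurement.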

Compound 3, percent growth inhibition at one concentration: 33.4%
For compound 3 the middle estimate is 2.6 percentage points above the measured one, and the stated range covers the measured number.
By their numbers in this assay, from the lowest: compounds 3, 1 and 2 (each within the scatter of the next).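

In this assay, among the compounds shown here, 3-cyanophenyl in place of 4-cyanophenyl on an aromatic nitrogen reads as a number 2.2 percentage points lower from compound 1 to compound 3 (within the scatter) and is the only single-place step available. On this evidence, the two cyanophenyl groups cannot be told apart at the one concentration tested, so moving the nitrile around this aryl ring is not shown to change growth inhibition in these cells. No accompanying measurement helps to explain this result.

The compounds shown leave open whether the ring place matters for groups other than nitrile, such as an amine or a carboxylic acid carried at the same two places on the aryl ring. They also leave open how the series responds to a change away from this aryl ring, such as a longer chain on the shared core, and whether the lack of separation between compound 1 and compound 3 would hold beyond the single concentration used.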